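The source may hold more compounds than are shown below. What is called first, only, known or untested is meant among the compounds shown, and "the series" means these compounds.

Working notes on the series.

Three compounds share one core and differ only in the group on an amine nitrogen in a ring. Compound 1 `Nc1scc(CN2CCN(c3ccc(Cl)cc3F)CC2)c1C(=O)c1ccc(Cl)cc1` gives in a functional assay on CHO cells with adenosine receptor A1 (Homo sapiens) as the target, read by cAMP accumulation and immunoassay, with a stated time of 6 min, tested at 10 uM (a lower number here means a stronger effect, a higher number a weaker effect of the compound at the concentration tested), a value of -81%. Compound 2 `Nc1scc(CN2CCN(c3ccncc3)CC2)c1C(=O)c1ccc(Cl)cc1` gives in this assay a value of -15%. Compound 3 `Nc1scc(CN2CCN(C3CCCCCC3)CC2)c1C(=O)c1ccc(Cl)cc1` gives in this assay a value of -25%. Compound 3 sits second highest of the three numbers; its nearest neighbour is compound 2, and that gap is within the scatter, while compound 1 lies farthest from it, beyond the scatter.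

Compound 4 `Nc1scc(CN2CCN(c3cccc4ccccc34)CC2)c1C(=O)c1ccc(Cl)cc1` is not yet measured. It differs from compound 3 as follows: naphthalen-1-yl in place of cycloheptyl on an amine nitrogen in a ring.

Within the data shown here, two measured steps bear on this change, both an aryl or aryl-like group against cycloheptyl on the same ring nitrogen. The step of a number 56 percentage points higher from compound 1 to compound 3 (beyond the scatter) is large. The step of a number 10 percentage points lower from compound 2 to compound 3 (within the scatter) is within the scatter. So the two aromatic groups pull in opposite directions relative to cycloheptyl, and the naphthalen-1-yl group, a carbon-only aromatic system like that of compound 1, is only loosely anchored by either. A downward step in this assay is expected, but with wide uncertainty. Compound 4 is expected to give about -50% in this assay, in the range -85% to -15%. The expected step is a number 25 percentage points lower from compound 3 to compound 4 (beyond the scatter).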

Compound 4, a percentage reported as activity, at one concentration (the size of the read-out at that concentration, not a potency): -21%
Estimate against measurement, compound 4: 29 percentage points below; measured number inside the range.
By their numbers in this assay, from the lowest: compound 1; then compounds 3, 4 and 2 (each within the scatter of the next).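

In this assay, the step from cycloheptyl to naphthalen-1-yl is a number 4 percentage points higher from compound 3 to compound 4 (within the scatter), and the step from pyridin-4-yl to naphthalen-1-yl is a number 6 percentage points lower from compound 2 to compound 4 (within the scatter), so these three groups on the amine nitrogen in a ring cannot be told apart at this concentration, despite their different rings. The step to naphthalen-1-yl from 4-chloro-2-fluorophenyl is a number 60 percentage points higher from compound 1 to compound 4 (beyond the scatter), which shows that an aromatic group of carbon rings on this nitrogen does not in itself bring a number near that of compound 1, which gives -81%; among the four compounds, only compound 1 stands apart. Nothing at hand accounts for this separation.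

The compounds shown leave open whether the number of compound 1 depends on the chlorine, the fluorine or both, a question that plain phenyl, 4-chlorophenyl and 2-fluorophenyl on the same nitrogen would address. They also leave open how naphthalen-2-yl would compare with naphthalen-1-yl, and, with a single tested concentration, whether compounds 2, 3 and 4 would show a stronger or weaker effect at any other concentration.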